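The source may report more compounds than this note shows. Statements on the series, on what has been measured and on what is new or still open speak of the compounds shown alone.

Measured so far in an ADME assay on CCRF-HSB-2 cells (Homo sapiens) for cytotoxicity, with a stated time of 7 days; a lower number here means that less compound is tolerated, a higher number that more compound is tolerated:
- compound 1, `Nc1nc(OCc2ccccc2)c2ncn(/C=C3/CC3(CO)CO)c2n1`: > 20000 nM — a limit of the assay, not a number
- compound 2, `CCCNc1nc(N)nc2c1ncn2/C=C1/CC1(CO)CO`: > 20000 nM — likewise a limit

Compound 2 therefore stands at the limit of this assay; its value is a limit and nothing more. Compound 3, `Nc1nc(SC2CCCC2)c2ncn(/C=C3/CC3(CO)CO)c2n1`, differs from it by cyclopentylsulfanyl in place of propylamino on an aromatic carbon.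

Among the measured compounds shown here, the one measured step, a step that the two limits leave unreadable from compound 1 to compound 2, cannot be read in size because of the limit of > 20000 nM in this assay, at which 2 of the 2 values shown sit. For the measured compounds named here, no measured step bears on the present change with a readable size, so the series gives no direction and no size to carry over. The expectation for compound 3 is that it again sits at the limit in this assay, with no step beyond the scatter, that is an expected step of a number no higher from compound 2 to compound 3 (the limit leaves the size open).

Estimate for compound 3 in this assay: expected 20000 nM, range 8000 nM to 60000 nM.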

Compound 3, half-maximal cytotoxic concentration: 91000 nM
Compound 3: middle estimate off by 4.6-fold (0.66 log units), on the low side; measured number outside the range, above it.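

In this assay no step can be read from compound 1 or compound 2 to compound 3, as the values of compound 1 and compound 2 are limits, not numbers: the limit of > 20000 nM in this assay, at which 2 of the 3 values shown sit.

The compounds shown leave open how far benzyloxy, propylamino and cyclopentylsulfanyl differ in this assay on the shared core.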